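The source may report more compounds than this note shows. Statements on the series, on what has been measured and on what is new or still open speak of the compounds shown alone.

Of the compounds shown here, three built on one shared core have been measured, and a fourth is waiting. Compound 1 `COc1ccc(C2=NNC(c3c(Cl)cccc3Cl)C2)cc1OC` and compound 2 `COc1ccc(C2=NNC(c3c(Cl)cccc3Cl)C2)cc1` differ in a single spot: hydrogen in place of methoxy on an aromatic carbon. In a functional assay on the whole organism (strain albino) for inhibition, with Rattus norvegicus as the target, read by paw edema, with stated times of 30 min and 3 h, at a dose of 100 mg/kg by the oral route (on this read-out higher numbers stand for more inhibition at the one dose given (going by the name of the read-out) and lower numbers for less inhibition), compound 1 gives 58%, and compound 2 gives 60%, so this change made a number 2 percentage points higher from compound 1 to compound 2 (within the scatter). Compound 3 `COc1ccc(C2=NN(C(=O)CO[N+](=O)[O-])C(c3c(Cl)cccc3Cl)C2)cc1OC` differs from compound 1 at the core itself, where (((nitrooxy)methyl)carbonyl in place of hydrogen on an amine nitrogen in a ring). In this assay compound 3 gives 58%, which amounts to no change at the digits printed from compound 1 to compound 3 (within the scatter). So far, neither change has moved the read-out beyond its usual scatter.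

Compound 4 `COc1ccc(C2=NN(C(=O)CO[N+](=O)[O-])C(c3c(Cl)cccc3Cl)C2)cc1` has not yet been measured. It stands to compound 3 exactly as compound 2 stands to compound 1: hydrogen in place of methoxy on an aromatic carbon. The surroundings of the changed spot read the same in both pairs, so this is the same change, and among the compounds shown it occurs twice in all. Among the compounds with values here, only one of those two occurrences has a measured result, and that single result is the only guide available here.

The expected step is a number 2 percentage points higher from compound 3 to compound 4 (within the scatter), because in the measured pair the same change made a number 2 percentage points higher from compound 1 to compound 2 (within the scatter). In this assay compound 4 is therefore estimated at 60%, with a likely range from 50% to 70%, an expectation that rests on a single earlier step and on compound 3 giving 58%.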

Compound 4, a percentage reported as inhibition, in the whole organism at one dose (the size of the read-out at that dose, not a potency): 52%
Estimate against measurement, compound 4: 8 percentage points above; low and high end bracket the measured number.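

Replacing methoxy with hydrogen, which turns 3,4-dimethoxyphenyl into 4-methoxyphenyl, gives in this assay a number 6 percentage points lower from compound 3 to compound 4 (within the scatter), and this step agrees with the same change on the core of compound 1: the same change on two cores in this assay, a number 2 percentage points higher (within the scatter) from compound 1 to compound 2 and a number 6 percentage points lower (within the scatter) from compound 3 to compound 4, 8 percentage points apart, within the scatter of two such steps. Putting ((nitrooxy)methyl)carbonyl in place of hydrogen on the ring nitrogen gives a number 8 percentage points lower from compound 2 to compound 4 (within the scatter), and this step also agrees with its earlier counterpart: the same change on two cores in this assay, no change at the digits printed (within the scatter) from compound 1 to compound 3 and a number 8 percentage points lower (within the scatter) from compound 2 to compound 4, 8 percentage points apart, within the scatter of two such steps. So, as far as these four compounds can tell, each change behaves alike on both cores, but all the steps are small enough to be lost in the scatter, which means the result does not show that either change has a real effect or that the steps on the two cores are truly identical.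

The compounds shown vary at only two spots, and all were read at a single dose, so a change large enough to stand clear of the scatter is still needed for a real test of carrying a step from one core to another. From the compounds shown here alone, it remains open how a hydroxy group or a fluorine atom on that aromatic carbon would read, or a longer chain in place of the ((nitrooxy)methyl)carbonyl group.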